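Swapping a Saturated Ring for Bromine

This account rests on a few compounds, and the source may have more. Where it says the series, first, only, none or still open, it means among the compounds named here.

Three compounds share one core and differ only in the group attached to one aromatic carbon of the fused ring system. In a functional assay on AGS cells (Homo sapiens) for antiproliferative activity, read by CCK-8 assay, with a stated time of 72 h (on this read-out higher numbers stand for weaker inhibition and lower numbers for stronger inhibition), compound 1 `CC(=O)N1CC=C(c2ccn3c(-c4ccc(NC(=O)c5ccc([N+](=O)[O-])o5)cc4)cnc3c2)CC1` gives 410 nM, compound 2 `CC1(O)CCN(c2ccn3c(-c4ccc(NC(=O)c5ccc([N+](=O)[O-])o5)cc4)cnc3c2)CC1` gives 1530 nM, and compound 3 `CN1CCCN(c2ccn3c(-c4ccc(NC(=O)c5ccc([N+](=O)[O-])o5)cc4)cnc3c2)CC1` gives 2700 nM. Compound 3 thus carries the highest number of the three: the step of a 6.6-fold higher number from compound 1 to compound 3 (0.82 log units; beyond the scatter) lies beyond the scatter, while the step of a 1.8-fold higher number from compound 2 to compound 3 (0.25 log units; within the scatter) does not.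

Compound 4 `O=C(Nc1ccc(-c2cnc3cc(Br)ccn23)cc1)c1ccc([N+](=O)[O-])o1` differs from compound 3 in one place: bromo in place of 4-methyl-1,4-diazepan-1-yl on an aromatic carbon. Going by the values given here, none of the measured steps swaps a saturated ring for a single halogen atom, so they bear only loosely on this change. They show that altering the group at this position moved this assay by at most a 6.6-fold higher number from compound 1 to compound 3 (0.82 log units; beyond the scatter), and that the two saturated rings with a second heteroatom gave numbers close together, as in a 1.8-fold higher number from compound 2 to compound 3 (0.25 log units; within the scatter). A step of similar size, in either direction, is therefore expected, estimated as a 1.8-fold lower number from compound 3 to compound 4 (0.26 log units; within the scatter). Compound 4 is expected to give about 1500 nM, in the range 400 nM to 6000 nM.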

Compound 4, half-maximal inhibitory concentration: 560 nM
For compound 4 the middle estimate is 2.7-fold (0.43 log units) above the measured one; measured number inside the range.
By their numbers in this assay, from the lowest: compounds 1 and 4 (each within the scatter of the next); then compounds 2 and 3 (each within the scatter of the next).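

In this assay this aromatic carbon does not need a saturated ring: a lone bromine in place of 4-methyl-1,4-diazepan-1-yl gives a 4.8-fold lower number from compound 3 to compound 4 (0.68 log units; beyond the scatter) and in place of 4-hydroxy-4-methylpiperidin-1-yl gives a 2.7-fold lower number from compound 2 to compound 4 (0.44 log units; beyond the scatter), both beyond the scatter. The size of the group does not order these numbers on its own, since the group of compound 1, the largest of the four, sits close to the single atom, with a 1.4-fold higher number from compound 1 to compound 4 (0.14 log units; within the scatter) within the scatter. Nothing measured here explains why the numbers fall this way.

Still open, going by these compounds, is whether another halogen, such as chlorine or fluorine, or a small open-chain amine such as dimethylamino, would match bromine at this carbon. Also open, on these data alone, is what the acetyl group of compound 1 contributes, which the same ring carrying a free amine could test.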